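A hydroxypropyl variant of a piperidinylamine indole series

The compounds below may be only part of what the source reports. "The series", "measured", "known", "first", "only" and "open" are said of these compounds alone.

Compound 1, `OC[C@H](NC1CCN(CCCc2c[nH]c3ccc(-n4ccnc4)cc23)CC1)c1ccccc1`, gives 0.8 nM in an assay on CHO cells for agonist activity at 5-hydroxytryptamine receptor 1D (Homo sapiens), read by GTPgammaS binding; a higher number here means that more compound is needed for the effect, a lower number that less compound is needed.
Compound 2, `COC[C@H](NC1CCN(CCCc2c[nH]c3ccc(-n4cnnc4)cc23)CC1)c1ccccc1`, gives 0.9 nM.
Compound 3, `CC(=O)Nc1ccc([C@H](C)NCC2CCN(CCCc3c[nH]c4ccc(-n5cnnc5)cc34)CC2)cc1`, gives 3 nM.

Among these three numbers compound 2 has the second highest. Its nearest neighbour is compound 1, whose number lies within the scatter of that of compound 2, so the two cannot be told apart. Compound 3 shows a higher number than compound 2 in this assay, and that gap lies beyond the scatter.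

The next compound, compound 4, `OCCC(NC1CCN(CCCc2c[nH]c3ccc(-n4cnnc4)cc23)CC1)c1ccccc1`, has not yet been measured. It differs from compound 2 in one place: 3-hydroxy-1-phenylpropyl in place of 2-methoxy-1-phenylethyl on an amine nitrogen. The atoms are the same; only their joining changes, and a hydrogen-bond donor appears where compound 2 had none.

Compound 1 already carries a hydroxyl on this side chain and gives 0.8 nM, so a hydroxyl in this region appears well tolerated. For compound 4 a step of about a 1.7-fold higher number from compound 2 to compound 4 (0.22 log units; within the scatter) is expected, which would be no change beyond the scatter or at most a slight rise in the number. The estimate for compound 4 in this assay is 1.5 nM, with a range from 0.5 nM to 5 nM.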

Compound 4, half-maximal effective concentration: 5.1 nM
For compound 4 the middle estimate is 3.4-fold (0.53 log units) below the measured one; measured number outside the range, above it.
By their numbers in this assay, from the lowest: compounds 1 and 2 (each within the scatter of the next); then compounds 3 and 4 (each within the scatter of the next).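

In this assay, replacing 2-methoxy-1-phenylethyl with 3-hydroxy-1-phenylpropyl on the amine nitrogen gives a 5.7-fold higher number from compound 2 to compound 4 (0.75 log units; beyond the scatter), so this position responds to how the same atoms are joined, even with the heavy-atom count unchanged. The change adds a hydrogen-bond donor, lengthens the path to the oxygen and loses the defined stereocentre all at once, and this single step cannot separate those differences. No measured information on the compounds accounts for the rise.

As far as these compounds go, whether the rise goes with the longer chain, the hydroxyl or the stereocentre remains open, and a 3-methoxy-1-phenylpropyl group on the core of compound 2 would help to separate the first two. From the compounds shown here alone, a single stereoisomer of compound 4 and a 3-amino-1-phenylpropyl group are also open questions at this position.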